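The compounds below may be only part of what the source reports. "The series", "measured", "known", "first", "only" and "open" are said of these compounds alone.

Measured compounds and their values:
compound 1 `CCCn1c(SCc2cc([N+](=O)[O-])ccc2OC)nc2cc(NC(=O)NC(C)(C)C)cc(C(=O)N(C)C)c21` — 200 nM
compound 2 `CCCn1c(SCc2cc([N+](=O)[O-])ccc2OC)nc2cc(NC(=O)NC(C)(C)C)cc(C(=O)NC)c21` — 23 nM

In an assay on isolated protein for inhibition of Gonadotropin-releasing hormone receptor (Rattus norvegicus) (on this read-out higher numbers stand for weaker inhibition and lower numbers for stronger inhibition), compound 2 gives 23 nM, the lowest of the two numbers. Compound 1 gives 200 nM. Among the measured compounds shown here, the only measured step, an 8.7-fold lower number from compound 1 to compound 2 (0.94 log units; beyond the scatter), shows that the substituent on the amide nitrogen matters: taking away the methyl there gave a clearly stronger compound.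

Compound 3 `CCCn1c(SCc2cc([N+](=O)[O-])ccc2OC)nc2cc(NC(=O)NC(C)(C)C)cc(C(=O)NCc3ccncc3)c21` has not been measured. It differs from compound 2 by pyridin-4-yl in place of hydrogen on a saturated chain carbon bound to an amide-type nitrogen, so the amide keeps its hydrogen but the methyl on the nitrogen grows into a (pyridin-4-yl)methyl group. For the measured compounds named here, the measured step from compound 1 to compound 2 tells of a change on the nitrogen itself, not of a larger group on the carbon beside it, so it bears on this step only indirectly; no measured pair tests an enlargement of that kind. The expectation is therefore a step of about a 2.0-fold higher number from compound 2 to compound 3 (0.29 log units; within the scatter), which would leave compound 3 within the scatter of compound 2 or somewhat weaker. For compound 3 the estimate in this assay is 45 nM, with a range from 10 nM to 200 nM.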

Compound 3, half-maximal inhibitory concentration: 35 nM
Beside the measured number, compound 3's estimate is 1.3-fold (0.11 log units) above it; the range from low to high includes it.
By their numbers in this assay, from the lowest: compounds 2 and 3 (each within the scatter of the next); then compound 1.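

In this assay the step to the larger group, a 1.5-fold higher number from compound 2 to compound 3 (0.18 log units; within the scatter), shows that the saturated chain carbon bound to an amide-type nitrogen can carry a pyridin-4-yl group, a whole six-membered aromatic ring, with no difference that stands clear of the usual scatter. Among the compounds shown here, the earlier pair showed only that the number rises when the amide hydrogen gives way to a second methyl, and the new comparison, a 5.7-fold lower number from compound 1 to compound 3 (0.76 log units; beyond the scatter), shows that the compound keeping the amide hydrogen stays clearly stronger than the dimethylamino amide even with the ring attached. No evidence at hand explains why the ring is tolerated here.

The compounds shown leave open whether the nitrogen of the ring counts for anything, a question that a plain phenyl ring in the same place, or a pyridin-2-yl or pyridin-3-yl group, would help to answer. They also leave open how much further this position can grow, for instance with a longer chain carrying the ring.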